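The source may report more compounds than this note shows. Statements on the series, on what has been measured and on what is new or still open speak of the compounds shown alone.

Working notes on the sigma series. Compound 1 `N=C(Nc1cccc2c1CCCC2)Nc1cccc2c1CCCC2` carries the tetrahydronaphthyl substituents on the guanidine core, and in an assay on membranes from brain (Cavia porcellus) for binding affinity to Sigma non-opioid intracellular receptor 1 (Homo sapiens) (on this read-out higher numbers stand for weaker inhibition and lower numbers for stronger inhibition), compound 1 gives 58.8 nM. Among the compounds with values here, compound 2 `ON=C(NC1CCCCC1)NC1CCCCC1` replaces both aryl groups with cyclohexyl and adds a hydroxy on the double-bonded nitrogen; in this assay compound 2 gives 271 nM, the highest of the two numbers so far, with compound 1 the nearest value and the gap between them beyond the usual scatter. Compound 3 `N=C(NC1CCCCC1)NC1CCCCC1` is not yet measured and differs from compound 2 by one change: hydrogen in place of hydroxy on a double-bonded nitrogen. Within the data shown here, no measured pair shows this exact step, so the direction is judged only from the two values in hand. The expectation for compound 3 is a modest move toward lower numbers, a step of a 3.4-fold lower number from compound 2 to compound 3 (0.53 log units; beyond the scatter), probably just beyond the scatter. Compound 3 is thus estimated at 80 nM, within a range of 25 nM to 250 nM.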

Compound 3, half-maximal inhibitory concentration: 71 nM
For compound 3 the middle estimate is 1.1-fold (0.05 log units) above the measured one; the measured number falls inside the stated range.
By their numbers in this assay, from the lowest: compounds 1 and 3 (each within the scatter of the next); then compound 2.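

Hydrogen in place of hydroxy on a double-bonded nitrogen now has a direct reading in this assay: with the cyclohexyl groups unchanged, the series shows a 3.8-fold lower number from compound 2 to compound 3 (0.58 log units; beyond the scatter) as a modest step beyond the scatter. This position therefore affects the read-out, and the hydroxy is not required for inhibition in this pair, since the compound with hydrogen gives the lower number. The data shown offer no explanation for the direction or size of this step.

Still open, from the compounds shown here alone, is how a methoxy group or an amino group on the same double-bonded nitrogen would compare with hydroxy and hydrogen. Also open, going by these compounds, is whether the same change gives a step of similar direction and size when the tetrahydronaphthyl substituents of compound 1 are present.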